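Swapping an aromatic ring for a short chain on the triazole

A few compounds are considered here, and "the series" means these few. Any claim that something is new, unique, unknown or untested is made for them only; others in the source may bear on it.

Of the compounds shown here, three sharing one core have been tested in a functional assay on MCF7 cells (Homo sapiens) for antiproliferative activity, read by MTT assay, with a stated time of 72 h; a lower number here means a stronger inhibitor, a higher number a weaker inhibitor. Compound 1 `O=C1O[C@H]([C@@H](O)Cn2cc(-c3cccc(O)c3)nn2)C(OCc2ccccc2)=C1OCc1ccccc1` gives 51800 nM. Compound 2 `O=C1O/C(=C\Cn2cc(-c3cccc(O)c3)nn2)C(OCc2ccccc2)=C1OCc1ccccc1` gives 27800 nM, and compound 3 `O=C1O[C@H]([C@@H](O)Cn2cc(-c3cc(C(F)(F)F)cc(C(F)(F)F)c3)nn2)C(OCc2ccccc2)=C1OCc1ccccc1` gives 45900 nM. Compound 1 carries the largest of the three numbers, yet the gaps to compound 3 and to compound 2 both fall within the usual scatter of repeated measurements, so none of the three can be called stronger or weaker than another; all sit at the weak end of what this assay detects.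

Compound 4 `CCCCc1cn(C[C@H](O)[C@H]2OC(=O)C(OCc3ccccc3)=C2OCc2ccccc2)nn1` has not yet been measured. Relative to compound 1, the change is butyl in place of 3-hydroxyphenyl on an aromatic carbon. No pair of measured compounds isolates this kind of change, so the expectation rests only on the three numbers shown, which stay close together despite different groups in that position. The step from compound 1 to compound 4 in this assay is therefore expected to be a 1.1-fold higher number from compound 1 to compound 4 (0.03 log units; within the scatter), with no change beyond the scatter favored. Compound 4 is estimated at 55000 nM, within a range of 20000 nM to 150000 nM.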

Compound 4, half-maximal inhibitory concentration: 7910 nM
Compound 4: middle estimate off by 7.0-fold (0.84 log units), on the high side; measured number below the stated range.
By their numbers in this assay, from the lowest: compound 4; then compounds 2, 3 and 1 (each within the scatter of the next).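

In this assay, for the compounds shown here, putting butyl in place of 3-hydroxyphenyl on the aromatic carbon of the five-membered ring gives a 6.5-fold lower number from compound 1 to compound 4 (0.82 log units; beyond the scatter), the only step here that lies beyond the scatter. For the core of compound 1, this position therefore does not need an aromatic ring or a hydroxyl group, since a four-carbon chain with neither gives the lower number. Nothing measured here explains why the number falls.

This single pair cannot separate the loss of the ring from the loss of the hydroxyl group, and a plain phenyl group would be needed to tell them apart. It also leaves open how a shorter ethyl chain, a longer hexyl chain or a saturated cyclohexyl ring would compare with butyl.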